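Methoxy in Place of Propylsulfanyl: Expected Shift in Activation

This account rests on a few compounds, and the source may have more. Where it says the series, first, only, none or still open, it means among the compounds named here.

Compound 1, `CCCSc1nc(N)c2nc(O)n(Cc3ccccc3)c2n1`: 0.01 uM
Compound 2, `Nc1ncnc2c1nc(I)n2Cc1ccccc1`: > 10 uM
Compound 3, `COc1ccccc1Cn1c(O)nc2c(N)ncnc21`: 10 uM

Of the compounds shown here, three have been tested in a functional assay (spleen, spleen) for activation, with Mus musculus as the target; on this read-out lower numbers stand for an effect already at smaller amounts and higher numbers for an effect only at larger amounts of compound. Compound 1 gives 0.01 uM, the lowest of the two numbers on record. Compound 3 gives 10 uM, a number far higher than that of compound 1, a gap well beyond the usual scatter of repeated measurements. Compound 2 gives no number at all but only a limit, > 10 uM (the limit of > 10 uM in this assay, at which 1 of the 3 values shown sits).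

Compound 4, `COc1nc(N)c2nc(O)n(Cc3ccccc3)c2n1`, has not yet been measured. It differs from compound 1 in a single place: methoxy in place of propylsulfanyl on an aromatic carbon. The rest of the shared core, with its amino group, its hydroxy group and its benzyl group, is kept unchanged.

No two measured compounds differ in just one place, so the size of this step has no direct precedent among the numbers shown. The step is nonetheless estimated as a 30-fold higher number from compound 1 to compound 4 (1.48 log units; beyond the scatter), a rise in the number that goes beyond the scatter, in the direction of an effect only at larger amounts. Compound 4 is therefore expected to give 0.3 uM, with a likely range from 0.03 uM to 3 uM.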

Compound 4, minimum effective concentration: 0.1 uM
Compound 4: the middle estimate sits 3.0-fold (0.48 log units) above what was measured, and the stated range covers the measured number.
By their numbers in this assay, from the lowest: compound 1; then compound 4; then compound 3.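

This position tolerates change better than the large gaps among the earlier numbers might suggest: with methoxy in place of propylsulfanyl on the aromatic carbon between two ring nitrogen atoms, this assay shows a 10-fold higher number from compound 1 to compound 4 (1.00 log units; beyond the scatter) as the first measured size for a single change on this core. The substituent can thus shrink from 4 heavy atoms to 2, with sulfur replaced by oxygen, and compound 4 still gives 0.1 uM as a clear measured number rather than a limit, though propylsulfanyl gives the lower number of the pair. Nothing shown here accounts for the size of this step.

The chain length and the linking atom change together in this pair, so the compounds shown cannot tell which of the two carries the step; propoxy, which keeps the propyl chain on oxygen, and methylsulfanyl, which keeps sulfur on a one-carbon chain, would pull the two apart. Also open, on these data alone, is how an amine or a longer chain such as pentylsulfanyl would fare at this same place on the shared core.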